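Chloro in Place of Trifluoromethyl on the Aryloxy Ring

A few compounds are considered here, and "the series" means these few. Any claim that something is new, unique, unknown or untested is made for them only; others in the source may bear on it.

Compound 2 `O[C@@H](COc1ccc(C(F)(F)F)cc1)CN1CCN(c2ccc(F)cc2)CC1` gives the highest inhibition of the two measured compounds in an assay on HEK293 cells for inhibition of Voltage-dependent T-type calcium channel subunit alpha-1G (Homo sapiens), read by patch clamp, tested at 10 uM (on this read-out higher numbers stand for more inhibition at the one concentration tested (going by the name of the read-out) and lower numbers for less inhibition), with 53.7%. Compound 1 `O[C@H](COc1ccc(Cl)cc1)CN1CCN(c2ccc(F)cc2)CC1`, which carries chloro rather than trifluoromethyl, gives 28.3% in this assay. Compound 3 `O[C@@H](COc1ccc(Cl)cc1)CN1CCN(c2ccc(F)cc2)CC1` is not yet measured; it is made from compound 2 by chloro in place of trifluoromethyl on an aromatic carbon. Among the measured compounds shown here, no measured pair shows this exact change, so the step is uncertain. A moderate drop in inhibition is expected, as the estimated step of a number 18.7 percentage points lower from compound 2 to compound 3 (beyond the scatter) suggests. Compound 3 is therefore estimated to give about 35%, within a range from 15% to 55%.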

Compound 3, a percentage reported as inhibition, at one concentration (the size of the read-out at that concentration, not a potency): 39.7%
For compound 3 the middle estimate is 4.7 percentage points below the measured one; the range from low to high includes it.
By their numbers in this assay, from the lowest: compound 1; then compound 3; then compound 2.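

In this assay chloro in place of trifluoromethyl gives a number 14 percentage points lower from compound 2 to compound 3 (beyond the scatter) with the stereocentre drawn R, so this position responds to the change. With chloro held fixed, the configuration also counts, giving a number 11.4 percentage points higher from compound 1 to compound 3 (beyond the scatter) and showing more inhibition for the R form. That second gap can be assigned to the stereocentre alone because of a single fact: the fact that compounds 1 and 3 differ only in the configuration as drawn.

The compounds shown leave open whether the stereocentre carries the same weight with trifluoromethyl on the ring. They also leave open how a nitrile or a methoxy group at this position would compare with chloro and trifluoromethyl.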